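Notes: 4-fluorophenyl for cyclopropyl on the sulfonyl sulfur

This account rests on a few compounds, and the source may have more. Where it says the series, first, only, none or still open, it means among the compounds named here.

In a functional assay on NCI-H460 cells (Homo sapiens) for cytotoxicity, read by MTT assay, with a stated time of 96 h (on this read-out lower numbers stand for stronger inhibition and higher numbers for weaker inhibition), compound 1 (`COc1ncc(-c2cc(OC)c3nc(N)nc(C)c3c2)cc1NS(=O)(=O)c1ccc(F)cc1F`) gives 280 nM and compound 2 (`COCCOc1cc(-c2cnc(OC)c(NS(=O)(=O)c3ccc(F)cc3F)c2)cc2c(C)nc(N)nc12`) gives 200 nM. Compound 3 (`COc1ncc(-c2cc(OC3CCOCC3)c3nc(N)nc(C)c3c2)cc1NS(=O)(=O)C1CC1`) gives 930 nM, the highest of the three numbers and beyond the scatter from both others.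

Compound 4 (`COc1ncc(-c2cc(OC3CCOCC3)c3nc(N)nc(C)c3c2)cc1NS(=O)(=O)c1ccc(F)cc1`) differs from compound 3 at one place, with 4-fluorophenyl in place of cyclopropyl on a sulfonyl sulfur.

Among the compounds with values here, no measured step isolates this change. Within the data shown here, the only measured step, a 1.4-fold lower number from compound 1 to compound 2 (0.15 log units; within the scatter), is methoxymethyl in place of hydrogen on a saturated chain carbon bound to an oxygen on an aromatic ring, and it lies within the scatter. It bears only indirectly, as a sign that a change away from the sulfonyl sulfur can leave the number nearly unmoved. Compound 1 and compound 2 carry a difluorophenyl group on the sulfonyl sulfur, but each also differs from compound 3 elsewhere, so the gap to 930 nM for compound 3 mixes more than one difference and offers only weak support. A lower number is still expected, and the estimated size is a 2.9-fold lower number from compound 3 to compound 4 (0.46 log units; beyond the scatter). For compound 4 the estimated value is 320 nM, with an expected range of 120 nM to 800 nM.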

Compound 4, half-maximal inhibitory concentration: 96 nM
Compound 4: the middle estimate sits 3.3-fold (0.52 log units) above what was measured, outside the stated range (below it).
By their numbers in this assay, from the lowest: compound 4; then compounds 2 and 1 (each within the scatter of the next); then compound 3.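

In this assay, within the data shown here, 4-fluorophenyl in place of cyclopropyl on the sulfonyl sulfur gives a 9.7-fold lower number from compound 3 to compound 4 (0.99 log units; beyond the scatter), and this is the first step that isolates this position, with the rest of compound 3 unchanged. Among these compounds, the number clearly responds to the group on the sulfonyl sulfur, whereas the only earlier step, a 1.4-fold lower number from compound 1 to compound 2 (0.15 log units; within the scatter), lies within the scatter and involves a change elsewhere in the structure; two steps are too few to call this a general pattern. Nothing available accounts for the size of the new step or for how the change acts on these cells.

A plain phenyl on the sulfonyl sulfur would help separate the contribution of the aromatic ring from that of the fluorine, while a methyl or a dimethylamino group there would show how the number responds to groups other than a carbon ring. Among the compounds shown here, it also remains open whether the same step holds when the ether group of compound 3 is replaced by those carried by compound 1 and compound 2, as the present compounds include no matched pair to test it.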